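A Methoxy Group Added at the Edge of Compound 3

The compounds below may be only part of what the source reports. "The series", "measured", "known", "first", "only" and "open" are said of these compounds alone.

Three compounds share one core and were tested in a functional assay on A549 cells (Homo sapiens) for inhibition, read by MTT assay, with a stated time of 72 h; on this read-out lower numbers stand for stronger inhibition and higher numbers for weaker inhibition. Compound 1, `CN1C(=O)N(c2ccccc2)C2NC(=S)N(/N=C/C=C/c3ccccc3)C21`, gives > 100000 nM, which is a limit of the assay and not a number; this is the limit of > 100000 nM in this assay, at which 1 of the 3 values shown sits. Compound 2, `CCN1C(=O)N(CC)C2C1NC(=S)N2/N=C/C=C/c1ccccc1`, gives 6530 nM in this assay. Compound 3, `CCN1C(=O)N(CC)C2C1N=C(SC)N2/N=C/C=C/c1ccccc1`, gives 21400 nM, the higher of the two numbers, and its number lies beyond the usual scatter from that of compound 2; no single change links these two, so only the two values themselves can be compared.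

Compound 4, `CCN1C(=O)N(CC)C2C1N=C(SC)N2/N=C/C=C/c1ccccc1OC`, has not yet been measured. It differs from compound 3 in one place: methoxy in place of hydrogen on an aromatic carbon, at the end of the chain bearing the aromatic ring, ortho to a large group. For the measured compounds named here, no measured pair shows what such a change does here, so the step from compound 3 to compound 4 is expected to stay within the scatter, a 1.1-fold lower number from compound 3 to compound 4 (0.03 log units; within the scatter), with no clear direction. Compound 4 is therefore expected to give about 20000 nM in this assay, between 7000 nM and 60000 nM.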

Compound 4, half-maximal inhibitory concentration: 4790 nM
Compound 4: the middle estimate sits 4.2-fold (0.62 log units) above what was measured; measured number below the stated range.
By their numbers in this assay, from the lowest: compounds 4 and 2 (each within the scatter of the next); then compound 3. At a limit, above all of these: compound 1.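

In this assay, the change from phenyl to 2-methoxyphenyl gives a 4.5-fold lower number from compound 3 to compound 4 (0.65 log units; beyond the scatter), so the aromatic ring at the end of the chain is a place where adding a small group can move the number beyond the scatter. The earlier compounds shown here all carry the same unsubstituted phenyl there and differ only elsewhere, so they could say nothing about this ring. What lies behind this step is not explained by anything measured here.

With only methoxy shown on this ring, it remains open whether a hydroxyl group, a chlorine atom or a longer ethoxy group at the same carbon would give a similar step, or whether methoxy would do so at another carbon of the ring. On these data alone, it also remains open whether the same change would act alike on compound 2, which differs from compound 3 in the core.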